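Ring contraction of the acetamidocycloalkyl amide: an expected outcome

The source may hold more compounds than are shown below. What is called first, only, known or untested is meant among the compounds shown, and "the series" means these compounds.

Measured compounds:
Compound 1, `CC(=O)N[C@@H]1CCC[C@H](C(=O)Nc2cc(-c3cnn4c3CCCC4)c(Cl)cn2)C1`, 46 uL/min
Compound 2, `CC(=O)N[C@@H]1CCC[C@H](C(=O)Nc2cc(-c3cnn4c3CCC4)c(Cl)cn2)C1`, 72 uL/min
Compound 3, `CC(=O)N[C@@H]1CCC[C@H](C(=O)Nc2cc(-c3cnn4c3CC(C)(C)C4)c(Cl)cn2)C1`, 73 uL/min

In an ADME assay on cells (Hepatocyte, Rattus norvegicus) for metabolic stability, using equilibrium dialysis (on this read-out lower numbers stand for slow clearance and higher numbers for fast clearance), compound 3 gives 73 uL/min. Its number cannot be separated from the other two: the step of a 1.0-fold higher number from compound 2 to compound 3 (0.01 log units; within the scatter) and the step of a 1.6-fold higher number from compound 1 to compound 3 (0.20 log units; within the scatter) both fall inside the scatter, as does a 1.6-fold higher number from compound 1 to compound 2 (0.19 log units; within the scatter). The three measured compounds therefore read as one cluster.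

Compound 4, `CC(=O)N[C@@H]1CC[C@H](C(=O)Nc2cc(-c3cnn4c3CC(C)(C)C4)c(Cl)cn2)C1`, is not yet measured. It differs from compound 3 in one place: 3-acetamidocyclopentyl in place of 3-acetamidocyclohexyl on a carbonyl carbon. Going by the values given here, none of the measured steps touches this part of the molecule; all three concern the bicyclic group on the aromatic carbon, and all three lie within the scatter. Among the compounds with values here, there is thus no measured step that bears on the change from compound 3 to compound 4, and the expectation rests only on the flatness of the cluster.

On that basis the step of a 1.0-fold lower number from compound 3 to compound 4 (0.02 log units; within the scatter) is expected to stay within the scatter. Compound 4 is estimated at 70 uL/min, with a range from 35 uL/min to 140 uL/min.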

Compound 4, intrinsic clearance in a liver preparation (reported as CLH), per the amount of preparation that the assay uses: 97 uL/min
Estimate against measurement, compound 4: 1.4-fold (0.14 log units) below, within the range that was stated.
By their numbers in this assay, from the lowest: compounds 1, 2, 3 and 4 (each within the scatter of the next, the first and the last beyond it).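

In this assay, the carbonyl side of the molecule now has a measured step of its own: a 1.3-fold higher number from compound 3 to compound 4 (0.12 log units; within the scatter). Replacing 3-acetamidocyclohexyl with 3-acetamidocyclopentyl on this carbonyl carbon therefore stays within the scatter, as the three steps in the group on the aromatic carbon also do, so this change cannot be separated from no change at all on this read-out. No measurement given here explains the result or shows what governs clearance in these compounds.

The compounds shown leave open whether the same ring change would stay within the scatter alongside the other two groups on the aromatic carbon, those of compound 1 and compound 2. They also leave open whether a carboxylic acid or a free amine in place of the acetamido group would move the number beyond the scatter.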